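This account rests on a few compounds, and the source may have more. Where it says the series, first, only, none or still open, it means among the compounds named here.

Measured compounds:
- compound 1 `Cc1ccccc1Cn1cc(COc2ccc3c(=O)ccoc3c2)nn1`: > 100000 nM (a limit of the assay)
- compound 2 `O=c1ccoc2cc(OCc3cn(Cc4ccccc4F)nn3)ccc12`: 29800 nM

In a functional assay on MDA-MB-231 cells (Homo sapiens) for cytotoxicity, read by MTT assay, with a stated time of 48 h (a lower number here means a stronger inhibitor, a higher number a weaker inhibitor), compound 2 gives 29800 nM, the only number shown. Compound 1 in this assay gives > 100000 nM, which is a limit of the assay (the limit of > 100000 nM in this assay, at which 1 of the 2 values shown sits). Among the compounds with values here, the single measured step is an at least 3.3-fold lower number from compound 1 to compound 2 (0.52 log units; beyond the scatter), a fluoro in place of methyl on an aromatic carbon.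

Compound 3 `N#Cc1cccc(Cn2cc(COc3ccc4c(=O)ccoc4c3)nn2)c1` differs from compound 2 by 3-cyanophenyl in place of 2-fluorophenyl on a saturated chain carbon bound to an aromatic nitrogen. Within the data shown here, no measured step covers this change, so the step from compound 1 to compound 2 bears on it only loosely. In this assay the step from compound 2 to compound 3 is expected to stay within the scatter, leaning weaker. Compound 3 is estimated at 40000 nM, with a range from 12000 nM to 130000 nM. The expected step is a 1.3-fold higher number from compound 2 to compound 3 (0.13 log units; within the scatter).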

Compound 3, half-maximal inhibitory concentration: > 100000 nM
Compound 3: only a limit was reported (the forecaster's own chance of this, stated with the estimate: 30%); at least 2.5-fold (0.39 log units) between middle value and limit.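

In this assay, 3-cyanophenyl in place of 2-fluorophenyl on a saturated chain carbon bound to an aromatic nitrogen gives an at least 3.3-fold higher number from compound 2 to compound 3 (0.52 log units; beyond the scatter). Compound 3 gives > 100000 nM, which is a limit of the assay. The step from compound 1 to compound 3 cannot be read, and among these benzyl variants only compound 2 carries a number, with the others at the same limit: the limit of > 100000 nM in this assay, at which 2 of the 3 values shown sit.

Open, on these data alone, is whether 3-fluorophenyl, 2-chlorophenyl or unsubstituted phenyl at this place would give a number. Also open, as far as these compounds go, is whether compound 1 and compound 3 differ at all beyond the limit.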